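Moving the Methyl Around the Aniline Ring

The source may report more compounds than this note shows. Statements on the series, on what has been measured and on what is new or still open speak of the compounds shown alone.

Measured so far:
compound 1, `Cc1cccc(Nc2nc(C)c(C(=O)/C=C/c3ccc(Cl)cc3)s2)c1`: > 25000 nM
compound 2, `Cc1ccccc1Nc1nc(C)c(C(=O)/C=C/c2ccccc2Cl)s1`: > 25000 nM

Of the compounds shown here, two have been tested in a functional assay on NCI-H460 cells (Homo sapiens) for cytotoxicity, read by MTT assay; a lower number here means a stronger inhibitor, a higher number a weaker inhibitor. In this assay compound 1 gives only a limit, > 25000 nM, and no number. Compound 2 likewise gives only a limit in this assay, namely > 25000 nM. Going by the values given here, compound 2 thus stands at the limit of > 25000 nM in this assay, at which 2 of the 2 values shown sit, as does every value measured so far; nothing separates the two measured compounds.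

Compound 3, `Cc1cccc(Nc2nc(C)c(C(=O)/C=C/c3ccccc3Cl)s2)c1`, is built from compound 2 by a single change: 3-methylphenyl in place of 2-methylphenyl on a nitrogen on an aromatic ring. The two have the same atoms, joined differently. Among the compounds with values here, no step between measured compounds is available to calibrate how much such a change can shift the read-out. Because compound 2 sits at the limit of > 25000 nM in this assay, at which 2 of the 2 values shown sit, compound 3 is expected to stay at that limit, with the step that the limit leaves unreadable from compound 2 to compound 3 expected to be none beyond the scatter. Compound 3 is therefore estimated at 40000 nM, within 10000 nM to 200000 nM.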

Compound 3, half-maximal inhibitory concentration: > 25000 nM
Compound 3 ended at the assay's limit; the forecaster's own chance of this, stated with the estimate: 80%; the middle value does not contradict the limit.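

Compound 1, compound 2 and compound 3 give no readable step between them in this assay, so the sizes of both changes stay unknown: the limit of > 25000 nM in this assay, at which 3 of the 3 values shown sit.

The compounds shown leave open whether moving the methyl or the chlorine around its ring shifts this read-out at all, with no actual number from any of them.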